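This account rests on a few compounds, and the source may have more. Where it says the series, first, only, none or still open, it means among the compounds named here.

Compound 1 `O=C(Nc1cc(Sc2ncn[nH]2)c(O)c2ccccc12)c1ccc(Cl)cc1` gives 43300 nM in a functional assay on HCT-116 cells (Homo sapiens) for antiproliferative activity, read by MTT assay, with a stated time of 48 h; on this read-out lower numbers stand for stronger inhibition and higher numbers for weaker inhibition.
Compound 2 `O=C(Nc1cc(Sc2ncn[nH]2)c(O)c2ccccc12)c1cccc(Cl)c1` gives > 100000 nM, which is a limit of the assay, not a number.
Compound 3 `Cc1cccc(C(=O)Nc2cc(Sc3ncn[nH]3)c(O)c3ccccc23)c1` gives > 100000 nM, again a limit of the assay.

Compound 1 thus stands as the only number shown; the other two values sit at the limit of > 100000 nM in this assay, at which 2 of the 3 values shown sit. The measured steps of an at least 2.3-fold higher number from compound 1 to compound 2 (0.36 log units; beyond the scatter) and an at least 2.3-fold higher number from compound 1 to compound 3 (0.36 log units; beyond the scatter) both change the aryl on the carbonyl carbon, while a step that the two limits leave unreadable from compound 2 to compound 3 stays unreadable. Compound 4 `O=C(Nc1cc(Sc2ncnc3nc[nH]c23)c(O)c2ccccc12)c1ccc(Cl)cc1` differs from compound 1 by a group of 9 heavy atoms (5 carbon, 4 nitrogen; one five-membered aromatic ring with 2 hetero atoms, one six-membered aromatic ring with 2 hetero atoms) in place of a group of 5 heavy atoms (2 carbon, 3 nitrogen; one five-membered aromatic ring with 3 hetero atoms), on a sulfur. Going by the values given here, no measured step touches the group on the sulfur, so the series gives no direction for this change; the expected step of a 1.1-fold lower number from compound 1 to compound 4 (0.03 log units; within the scatter) is therefore none beyond the scatter, with wide uncertainty. Compound 4 is expected to give 40000 nM, estimated between 8000 nM and 200000 nM.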

Compound 4, half-maximal inhibitory concentration: > 100000 nM
Compound 4 was reported as a limit; the forecaster's own chance of this, stated with the estimate: 35%; middle value at least 2.5-fold (0.39 log units) away from the limit.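

Going by these compounds alone, replacing the 1H-1,2,4-triazol-5-yl on the sulfur with the group of 9 heavy atoms gives, in this assay, an at least 2.3-fold higher number from compound 1 to compound 4 (0.36 log units; beyond the scatter), the first readable evidence that activity depends on the group at this place as well as on the aryl on the carbonyl carbon. Compound 4 gives a limit of the assay, not a number, so the full size of the step stays unreadable. The series now has a single numeric value: the limit of > 100000 nM in this assay, at which 3 of the 4 values shown sit.

On these data alone, whether a simple amine or a carboxylic acid on the sulfur would give a lower number than compound 1 remains open. Also open, as far as these compounds go, is whether any group at this place would bring the number down at all.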